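Swapping a Benzyl Arm for a Fluorophenyl Ring

This account rests on a few compounds, and the source may have more. Where it says the series, first, only, none or still open, it means among the compounds named here.

Compound 1 `COc1ccc(F)cc1CNCCCNc1ccnc2cc(Cc3cc(C)cc(C)c3)ccc12` is measured in an ADME assay for permeability, using PAMPA, with a stated time of 30 min, at pH 7.4 (a higher number here means that the compound crosses the layer faster, a lower number that the compound crosses the layer more slowly), where compound 1 gives 23 10^-6 cm/s. Compound 3 `Cc1cc(C)cc(Cc2ccc3c(NCCCNCc4ccco4)ccnc3c2)c1` gives 23 10^-6 cm/s, so the two stand level at the digits shown, together the lowest of the three numbers. Within the data shown here, the one measured step, no change at the digits printed from compound 1 to compound 3 (within the scatter), alters the group on the saturated chain carbon bound to an amine nitrogen and leaves the aromatic carbon untouched. Compound 2 `COc1cccc(CNCCCNc2ccnc3cc(-c4cc(C(F)(F)F)cc(C(F)(F)F)c4)ccc23)c1O` gives 237 10^-6 cm/s, the highest of the three, but compound 2 differs from compound 1 in more than one place, so its higher number cannot be tied to any single change.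

Compound 4 `COc1ccc(F)cc1CNCCCNc1ccnc2cc(-c3ccc(F)cc3)ccc12` is not yet measured. It differs from compound 1 thus: 4-fluorophenyl in place of 3,5-dimethylbenzyl on an aromatic carbon. Among the measured compounds shown here, no measured step touches this place, and the step from compound 1 to compound 3 speaks only of a different change. Compound 2 carries a ring bound directly to the core and shows a high number, yet its other differences leave the question open. A modest rise is therefore expected, a 2.0-fold higher number from compound 1 to compound 4 (0.29 log units; within the scatter). Compound 4 is estimated at 45 10^-6 cm/s, with a range from 15 10^-6 cm/s to 130 10^-6 cm/s.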

Compound 4, apparent permeability: 237 10^-6 cm/s
Compound 4: the middle estimate sits 5.3-fold (0.72 log units) below what was measured, and the stated range ends below it.
By their numbers in this assay, from the lowest: compounds 1 and 3 (each within the scatter of the next); then compounds 2 and 4 (each within the scatter of the next).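

In this assay the aromatic carbon of the shared core proves to be a place where a change counts: 4-fluorophenyl in place of 3,5-dimethylbenzyl gives a 10-fold higher number from compound 1 to compound 4 (1.01 log units; beyond the scatter) and so a step well beyond the scatter. Among these compounds, the only earlier step gave no change at the digits printed from compound 1 to compound 3 (within the scatter) at the saturated chain carbon, a different place, so this is the first single change seen to move the number. Nothing available here gives a cause for the rise.

This one step changes several things at once, as the linking carbon of the benzyl group and the methyl groups leave and a fluorine enters, and it cannot say which of these matters. As far as these compounds go, a 3,5-dimethylphenyl or a 4-fluorobenzyl group on this carbon would pull these changes apart, and how either would read remains open.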